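The compounds below may be only part of what the source reports. "The series", "measured", "known", "first", "only" and "open" are said of these compounds alone.

Measured so far in an assay on membranes from HeLa cells for displacement of a labelled ligand from adenosine receptor A3 (Homo sapiens), read by scintillation counting, with a stated time of 180 min, tested at 1 uM; a lower number here means less inhibition, a higher number more inhibition at the concentration tested (going by the name of the read-out):
compound 1 `CC1=C(C(=O)OCc2ccccc2)C(c2ccco2)NC(=O)N1`: 3%
compound 2 `CC1=C(C(=O)OCc2ccccc2)C(c2ccoc2)NC(=O)N1`: 1%
compound 3 `CC1=C(C(=O)OCc2ccccc2)C(c2ccoc2)NC(=O)N1C`: 25%

Compound 2 sits at the low end of these three numbers. Within the data shown here, the only step beyond the scatter is a number 24 percentage points higher from compound 2 to compound 3 (beyond the scatter); the other measured step, a number 2 percentage points lower from compound 1 to compound 2 (within the scatter), stays inside it.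

Compound 4 `CCC(C)OC(=O)C1=C(C)NC(=O)NC1c1ccoc1` differs from compound 2 in one place: sec-butyl in place of benzyl on an oxygen next to a carbonyl group. Neither measured step touches the oxygen next to a carbonyl group; one varied the furan attachment, the other the amide-type nitrogen in the ring. Among the measured compounds shown here, no step at this position is available as a guide, so no change beyond the scatter is expected in this assay. Compound 4 is estimated at 3%, range -8% to 15%. The expected step is a number 2 percentage points higher from compound 2 to compound 4 (within the scatter).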

Compound 4, a percentage reported as inhibition, at one concentration (the size of the read-out at that concentration, not a potency): 11%
The estimate for compound 4 lay 8 percentage points below the measured number; the measured number falls inside the stated range.
By their numbers in this assay, from the lowest: compounds 2, 1 and 4 (each within the scatter of the next); then compound 3.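

In this assay, among these compounds, the first change at the oxygen next to a carbonyl group, sec-butyl in place of benzyl, gives a number 10 percentage points higher from compound 2 to compound 4 (within the scatter), so this pair stays within the scatter. Here the six-membered aromatic ring of benzyl can be lost, and 7 heavy atoms replaced by 4, without a step beyond the scatter. No supporting evidence bears on this result.

Open, on these data alone, is whether a longer chain, or a chain ending in an amine or a carboxylic acid, would move the number beyond the scatter at this oxygen. Also open, as far as these compounds go, is how sec-butyl behaves on the core of compound 3, with its methyl on the amide-type nitrogen.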